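Compound 2 gains a cyclopropyl group

The source may report more compounds than this note shows. Statements on the series, on what has been measured and on what is new or still open speak of the compounds shown alone.

Values so far in an ADME assay (liver) for metabolic stability, with Liver microsome (Rattus norvegicus) as the target, using microsomes (on this read-out higher numbers stand for fast clearance and lower numbers for slow clearance), for the measured compounds:
- Compound 1 `c1ccc(CNc2nnc(-c3c[nH]c4ncccc34)o2)cc1` gives 40 mL.min-1.g-1
- Compound 2 `Fc1ccccc1CNc1nnc(-c2c[nH]c3ncccc23)o1` gives 46 mL.min-1.g-1

These two compounds differ by fluoro in place of hydrogen on an aromatic carbon. Within the data shown here, that change gave a 1.2-fold higher number from compound 1 to compound 2 (0.06 log units; within the scatter) and is the only measured step, so compound 2 stands level with compound 1 once the usual scatter is allowed for.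

Compound 3 `Fc1ccccc1[C@H](Nc1nnc(-c2c[nH]c3ncccc23)o1)C1CC1` has not been measured yet. Its difference from compound 2 is cyclopropyl in place of hydrogen on a saturated chain carbon bound to an aromatic carbon and a nitrogen on an aromatic ring and it puts cyclopropyl in place of hydrogen on a saturated chain carbon bound to an aromatic carbon and a nitrogen on an aromatic ring. Among the measured compounds shown here, the one measured step concerns another change in another place, and no measured compound carries a cyclopropyl, so it offers no direct guide. The best anchor is compound 2 at 46 mL.min-1.g-1 and only a small upward move in this assay is expected, possibly none beyond the scatter. The expected step is a 1.3-fold higher number from compound 2 to compound 3 (0.12 log units; within the scatter) and this remains an estimate. Compound 3 is expected at 60 mL.min-1.g-1 with an estimated range from 25 mL.min-1.g-1 to 140 mL.min-1.g-1 until it is measured.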

Compound 3, intrinsic clearance in microsomes: 63 mL.min-1.g-1
The estimate for compound 3 lay 1.1-fold (0.02 log units) below the measured number; the range from low to high includes it.
By their numbers in this assay, from the lowest: compounds 1, 2 and 3 (each within the scatter of the next).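

In this assay, cyclopropyl in place of hydrogen on a saturated chain carbon bound to an aromatic carbon and a nitrogen on an aromatic ring gives a 1.4-fold higher number from compound 2 to compound 3 (0.14 log units; within the scatter). Among these compounds, this is the first reading at this position, and it shows that a three-membered non-aromatic ring of 3 heavy atoms can enter there with a step that stays within the usual scatter of repeated measurements, just as a 1.2-fold higher number from compound 1 to compound 2 (0.06 log units; within the scatter) did for fluoro on an aromatic carbon. No measurement shown here offers an explanation for the size of this step, so the result describes what happened at this position without saying why.

Going by these compounds, a single group at this position cannot show how the read-out responds to other kinds of group, so it remains open whether an amine, a carboxylic acid or a longer chain on the same carbon would give a step beyond the scatter. Also open, on these data alone, is how the mirror-image form of compound 3, with the cyclopropyl pointing the opposite way, would read in this assay.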